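A few compounds are considered here, and "the series" means these few. Any claim that something is new, unique, unknown or untested is made for them only; others in the source may bear on it.

Working notes on the series, read in a toxicity assay on L02 cells (Homo sapiens) for cytotoxicity, read by MTT assay, with a stated time of 72 h; on this read-out higher numbers stand for weaker inhibition and lower numbers for stronger inhibition. Among the compounds with values here, compound 1 `O=C1c2c[n+]([O-])c3ccccc3c2C(=O)c2c1c1ccccc1n2Cc1cn(C[C@H](O)CO)nn1` gives 1130 nM and compound 2 `CC1(C)O[C@@H](CO)[C@H](Cn2cc(Cn3c4c(c5ccccc53)C(=O)c3c[n+]([O-])c5ccccc5c3C4=O)nn2)O1` gives 500 nM, so compound 2 holds the lower of the two numbers so far. Next comes compound 3 `O=C1c2c[n+]([O-])c3ccccc3c2C(=O)c2c1c1ccccc1n2Cc1cn([C@@H]2O[C@H](CO)[C@@H](O)[C@H](O)[C@H]2O)nn1`, which keeps the shared core of compound 2 and differs in the group on an aromatic nitrogen of a five-membered aromatic ring with 3 nitrogen: 3,4,5-trihydroxy-6-(hydroxymethyl)oxan-2-yl in place of (5-(hydroxymethyl)-2,2-dimethyl-1,3-dioxolan-4-yl)methyl on an aromatic nitrogen. Within the data shown here, only one measured step bears on this change: a 2.3-fold lower number from compound 1 to compound 2 (0.35 log units; beyond the scatter). That step is modest but beyond the scatter, with the 5-(hydroxymethyl)-2,2-dimethyl-1,3-dioxolan-4-yl group entering in place of 1,2-dihydroxyethyl. Compound 3 gives up that dioxolanyl group and carries free hydroxy groups, as compound 1 does at 1130 nM, so a modest step to a higher number is expected in this assay. Among the measured compounds shown here, this rests on a single step, and no measured compound yet carries the oxanyl group. For compound 3 the expected value is 1200 nM, within an estimated range of 400 nM to 4000 nM. The estimate amounts to an expected 2.4-fold higher number from compound 2 to compound 3 (0.38 log units; beyond the scatter).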

Compound 3, half-maximal inhibitory concentration: 420 nM
The estimate for compound 3 lay 2.9-fold (0.46 log units) above the measured number; the measured number falls inside the stated range.
By their numbers in this assay, from the lowest: compounds 3 and 2 (each within the scatter of the next); then compound 1.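

In this assay the change on an aromatic nitrogen to 3,4,5-trihydroxy-6-(hydroxymethyl)oxan-2-yl from (5-(hydroxymethyl)-2,2-dimethyl-1,3-dioxolan-4-yl)methyl gives a 1.2-fold lower number from compound 2 to compound 3 (0.08 log units; within the scatter) and so leaves the two groups indistinguishable here, although the entering group has 4 hydrogen-bond donors and the leaving group has 1. Free hydroxy groups therefore do not by themselves go with the higher number: compound 1 and compound 3 both carry them, yet the change from 2,3-dihydroxypropyl to the oxanyl group gives a 2.7-fold lower number from compound 1 to compound 3 (0.43 log units; beyond the scatter) and compound 1 stands apart from the other two. No supporting data bear on why these groups read as they do.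

Within the data shown here, with only three groups at this position, and with compound 2 and compound 3 differing in both ring and hydroxy groups, it remains open which feature of the groups tracks the reading. Also open, as far as these compounds go, is how an amine, a carboxylic acid or a plain butyl chain on the same aromatic nitrogen would read in this assay against these three compounds.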